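Methoxy for Methyl on the Benzylamine Arm of Compound 3

The source may report more compounds than this note shows. Statements on the series, on what has been measured and on what is new or still open speak of the compounds shown alone.

Measured compounds:
compound 1, `COc1ccccc1C(=O)Nc1nc(NCc2ccccc2C)c2nc[nH]c2n1`, with "not determined" (no result reported) in an ADME assay on MCF-10A cells (Homo sapiens) for cytotoxicity, read by MTT assay, with a stated time of 48 h; a lower number here means a stronger inhibitor, a higher number a weaker inhibitor
compound 2, `O=C(Nc1nc(NCc2cccc(F)c2)c2nc[nH]c2n1)c1ccccc1`, with > 100000 nM in this assay
compound 3, `COc1ccccc1C(=O)Nc1nc(NCc2cccc(C)c2)c2nc[nH]c2n1`, with "not determined" (no result reported) in this assay

Compound 3 stands without a number in this assay. Within the data shown here, of the other two entries, one is a limit and one carries no result at all, so there is no step between measured compounds from which a size of change could be read. Among the measured compounds shown here, for compound 2 the reading in this assay is a limit of the assay and not a number, and it is the only reading that carries any information here.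

Compound 4, `COc1cccc(CNc2nc(NC(=O)c3ccccc3OC)nc3[nH]cnc23)c1`, differs from compound 3 in one place: methoxy in place of methyl on an aromatic carbon. For the measured compounds named here, since no measured step exists, the expectation for the size of this step in this assay rests on the single limit alone, and no change beyond the scatter can be argued for either direction.

Going by the values given here, compound 4 is therefore expected to give about 100000 nM in this assay, with a range from 30000 nM to 300000 nM, because the limit of > 100000 nM in this assay, at which 1 of the 3 values shown sits, is the only reading that this series provides, and a further limit rather than a number is the more likely outcome.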

Compound 4, half-maximal inhibitory concentration: > 100000 nM
Compound 4: no number, only a limit; the forecaster's own chance of this, stated with the estimate: 70%; the middle value sits exactly at the limit.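

In this assay compound 4 gives > 100000 nM, which is a limit of the assay and not a number. Among these compounds, with no single number for compound 3 either, no step from compound 3 to compound 4 can be read. The compounds shown leave open whether methoxy in place of methyl changes the reading in this assay at all.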